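Tetrazole-pyridine replaces methyltriazole-phenyl in a pituitary cell assay

A few compounds are considered here, and "the series" means these few. Any claim that something is new, unique, unknown or untested is made for them only; others in the source may bear on it.

Measured so far:
Compound 1, `CC(C)(N)CC(=O)N[C@@H]1CCc2ccccc2N(Cc2ccc(-c3ccccc3-c3nc[nH]n3)cc2)C1=O`: 90 nM
Compound 2, `Cn1ncnc1-c1ccccc1-c1ccc(CN2C(=O)[C@H](NC(=O)CC(C)(C)N)CCc3ccccc32)cc1`: 265 nM

Among the measured compounds shown here, in a functional assay (Pituitary gland cell) with Rattus norvegicus as the target (on this read-out higher numbers stand for an effect only at larger amounts of compound and lower numbers for an effect already at smaller amounts), compound 2 gives the highest of the two numbers; the only other compound, compound 1, sits lower by a 2.9-fold higher number from compound 1 to compound 2 (0.47 log units; beyond the scatter). Compound 3, `CC(C)(N)CC(=O)N[C@@H]1CCc2ccccc2N(Cc2ccc(-c3cccnc3-c3nn[nH]n3)cc2)C1=O`, is not yet measured; it carries 2-(2H-tetrazol-5-yl)pyridin-3-yl in place of 2-(1-methyl-1H-1,2,4-triazol-5-yl)phenyl on an aromatic carbon. For the measured compounds named here, no measured step changes this whole two-ring portion, so the one known step, which removed a methyl from the triazole and lowered the number, is only loosely related. Because compound 1 with its unsubstituted ring gave 90 nM, compound 3 is expected to move by a 2.0-fold lower number from compound 2 to compound 3 (0.31 log units; beyond the scatter). Compound 3 is estimated at 130 nM, within 40 nM to 400 nM.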

Compound 3, half-maximal effective concentration: 2350 nM
Estimate against measurement, compound 3: 18-fold (1.26 log units) below, outside the stated range (above it).
By their numbers in this assay, from the lowest: compound 1; then compound 2; then compound 3.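

In this assay this position does not accept every ring pair of this kind equally: the change to 2-(2H-tetrazol-5-yl)pyridin-3-yl gives an 8.9-fold higher number from compound 2 to compound 3 (0.95 log units; beyond the scatter) and, against the unmethylated triazole, a 26-fold higher number from compound 1 to compound 3 (1.42 log units; beyond the scatter). Both rings change at once in this swap, so the loss cannot be assigned to the pyridine nitrogen or to the tetrazole alone. No measurement here explains the loss.

Still open, from the compounds shown here alone, is which ring carries it. A phenyl ring bearing the tetrazole, or a carboxylic acid in the tetrazole's place, would help to separate the two.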